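This account rests on a few compounds, and the source may have more. Where it says the series, first, only, none or still open, it means among the compounds named here.

Three ureas share one core, a trimethoxyphenyl joined through a urea to a second benzene ring, and differ only in what that second ring carries. Compound 1, `COc1cc(NC(=O)Nc2cccc(F)c2)cc(OC)c1OC`, bears a fluorine on it; compound 2, `COc1cc(NC(=O)Nc2ccccc2)cc(OC)c1OC`, bears nothing extra; compound 3, `COc1cc(NC(=O)Nc2cccc([N+](=O)[O-])c2)cc(OC)c1OC`, bears a nitro group.

In a functional assay on ONS-76 cells (Homo sapiens) for cytotoxicity, read by MTT assay, with a stated time of 72 h (a higher number here means a weaker inhibitor, a lower number a stronger inhibitor), compound 1 gives 65600 nM, a weak result. For compound 2 the same test was run, but the entry for compound 2 reads "not determined" (no result reported), so compound 2 stands without any number of its own, and nothing can be said about how it compares with compound 1.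

The move from compound 2 to compound 3 is a single exchange: nitro in place of hydrogen on an aromatic carbon. Within the data shown here, no measured pair in this set shows what such an exchange does here, so the size and direction of the step remain open. Among the measured compounds shown here, the only anchor is compound 1, whose weak value suggests that small substituents on this ring leave the core weak in this assay.

On that basis compound 3 is expected to give about 40000 nM in this assay, with a likely range from 10000 nM to 150000 nM.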

Compound 3, half-maximal inhibitory concentration: 79600 nM
For compound 3 the middle estimate is 2.0-fold (0.30 log units) below the measured one, within the range that was stated.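

In this assay, putting nitro in place of fluoro on an aromatic carbon, meta to a large group, gives a 1.2-fold higher number from compound 1 to compound 3 (0.08 log units; within the scatter), so compound 1 and compound 3 cannot be told apart in this test. Among these compounds, at this place on the ring, then, a single fluorine atom and a nitro group of 3 heavy atoms leave the shared core in the same weak range, which is what a second measured compound adds to the single value available before. No measurement at hand bears on why the two compounds read alike.

From the compounds shown here alone, compound 2 has no number, so the steps that would lead from it to compound 1 or compound 3 cannot be read, and whether either group differs at all from plain hydrogen stays unknown. Also open, going by these compounds, is whether a quite different group at this place, such as an amine, a carboxylic acid or a longer chain, would move the value out of this weak range.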